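Sulfonamide in place of the decyl chain on the triazole

This account rests on a few compounds, and the source may have more. Where it says the series, first, only, none or still open, it means among the compounds named here.

Of the compounds shown here, three built on a shared core have been measured in a functional assay on A549 cells (Homo sapiens) for antiproliferative activity, read by MTT assay, with a stated time of 72 h; a lower number here means a stronger inhibitor, a higher number a weaker inhibitor. Compound 1 `O=C1O[C@H]([C@@H](O)Cn2cc(-c3ccc(Br)cc3)nn2)C(OCc2ccccc2)=C1OCc1ccccc1` gives 750 nM. Compound 2 `O=C1O[C@H]([C@@H](O)Cn2cc(-c3cccc(O)c3)nn2)C(OCc2ccccc2)=C1OCc1ccccc1` gives 59900 nM, and compound 3 `CCCCCCCCCCc1cn(C[C@H](O)[C@H]2OC(=O)C(OCc3ccccc3)=C2OCc2ccccc2)nn1` gives 6750 nM, which places compound 3 second highest of the three numbers, between compound 2 and compound 1. The steps to it were a 9.0-fold higher number from compound 1 to compound 3 (0.95 log units; beyond the scatter) and an 8.9-fold lower number from compound 2 to compound 3 (0.95 log units; beyond the scatter), while an 80-fold higher number from compound 1 to compound 2 (1.90 log units; beyond the scatter) was the largest change seen.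

Compound 4 `O=C1O[C@H]([C@@H](O)Cn2cc(CNS(=O)(=O)c3ccc(Cl)cc3)nn2)C(OCc2ccccc2)=C1OCc1ccccc1` differs from compound 3 in that (((4-chlorophenyl)sulfonyl)amino in place of nonyl on a saturated chain carbon bound to an aromatic carbon). Going by the values given here, no measured step matches this exchange; the nearest comparisons are the steps from compound 1 and compound 2 to compound 3, each of modest size and in opposite directions. The entering group brings a six-membered aromatic ring of carbon only, one hydrogen-bond donor and two hydrogen-bond acceptors, which is not paralleled among the measured compounds. The author therefore expects only a small step, a 1.5-fold higher number from compound 3 to compound 4 (0.17 log units; within the scatter), with wide uncertainty. For compound 4 the estimate in this assay is 10000 nM, within a range of 2000 nM to 60000 nM.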

Compound 4, half-maximal inhibitory concentration: 2870 nM
Beside the measured number, compound 4's estimate is 3.5-fold (0.54 log units) above it; the measured number falls inside the stated range.
By their numbers in this assay, from the lowest: compound 1; then compound 4; then compound 3; then compound 2.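

In this assay, placing ((4-chlorophenyl)sulfonyl)amino on a saturated chain carbon bound to an aromatic carbon, in place of nonyl, gives a 2.4-fold lower number from compound 3 to compound 4 (0.37 log units; beyond the scatter), the first sign that a group carrying a sulfonyl and an amino hydrogen at the end of this short link can improve on the long alkyl chain. Against the groups set directly on the aromatic carbon, the result is mixed: a 21-fold lower number from compound 2 to compound 4 (1.32 log units; beyond the scatter), yet a 3.8-fold higher number from compound 1 to compound 4 (0.58 log units; beyond the scatter), so 4-bromophenyl keeps the lowest number of the four. No evidence is available that accounts for this order.

As far as these compounds go, it remains open whether the gain rests on the sulfonyl unit, the 4-chlorophenyl ring or the chlorine itself. An amide in place of the sulfonamide, or an unsubstituted phenyl on the sulfur, would begin to separate these parts.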